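Replacing (methylsulfonyl)oxy with fluoro in compound 1

The compounds below may be only part of what the source reports. "The series", "measured", "known", "first", "only" and "open" are said of these compounds alone.

- compound 1 `CS(=O)(=O)OC[C@H]1OC(n2cc(F)c(=O)[nH]c2=O)[C@H](O)[C@@H]1O`: 660 nM
- compound 2 `[N-]=[N+]=NC[C@H]1OC(n2cc(F)c(=O)[nH]c2=O)[C@H](O)[C@@H]1O`: 350000 nM
- compound 3 `NC[C@H]1OC(n2cc(F)c(=O)[nH]c2=O)[C@H](O)[C@@H]1O`: 49000 nM

All three compounds were tested in a functional assay on CCRF-CEM cells (Homo sapiens) for inhibition; a higher number here means a weaker inhibitor, a lower number a stronger inhibitor. Compound 1 stands lowest, and its steps to the other two lie beyond the scatter. Compound 4 `O=c1[nH]c(=O)n(C2O[C@H](CF)[C@@H](O)[C@H]2O)cc1F` is still unmeasured. Its structure departs from compound 1 thus: fluoro in place of (methylsulfonyl)oxy on a saturated chain carbon bound to a saturated ring carbon, with fluoro in place of (methylsulfonyl)oxy on a saturated chain carbon bound to a saturated ring carbon. Two measured steps replace the same group, both large: a 530-fold higher number from compound 1 to compound 2 (2.72 log units; beyond the scatter) and a 74-fold higher number from compound 1 to compound 3 (1.87 log units; beyond the scatter). A modest gap separates those two replacements: a 7.1-fold lower number from compound 2 to compound 3 (0.85 log units; beyond the scatter). Within the data shown here, no measured compound carries fluoro at this place, so the parallel is indirect. A large rise is therefore expected, estimated as a 45-fold higher number from compound 1 to compound 4 (1.66 log units; beyond the scatter). The estimate for compound 4 is 30000 nM, with an expected range of 3000 nM to 300000 nM.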

Compound 4, half-maximal inhibitory concentration: 140000 nM
Beside the measured number, compound 4's estimate is 4.7-fold (0.67 log units) below it, and the stated range covers the measured number.
By their numbers in this assay, from the lowest: compound 1; then compound 3; then compound 4; then compound 2.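

In this assay, fluoro at this place also gives a far weaker inhibitor, with a 210-fold higher number from compound 1 to compound 4 (2.33 log units; beyond the scatter), so all three replacements now sit well above compound 1. The replacements stay closer to one another, with a 2.9-fold higher number from compound 3 to compound 4 (0.46 log units; beyond the scatter) and a 2.5-fold lower number from compound 2 to compound 4 (0.40 log units; beyond the scatter), both modest yet beyond the scatter. Among the four groups compared at this place, only (methylsulfonyl)oxy gives the low number. No measurement shown accounts for this. From the compounds shown here alone, whether chloro or a longer sulfonate such as (ethylsulfonyl)oxy would keep the low number remains open.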